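From cyano to fluoro on the aromatic ring

A few compounds are considered here, and "the series" means these few. Any claim that something is new, unique, unknown or untested is made for them only; others in the source may bear on it.

Measured compounds:
Compound 1 `C/N=C(\S)[C@]1(c2cccc(C(F)(F)F)c2)CCCC[S+]1[O-]` - 800 nM
Compound 2 `C/N=C(\S)[C@]1(c2cccc(C#N)c2)CCCC[S+]1[O-]` - 1600 nM

Among the measured compounds shown here, in a functional assay (aorta) for inhibition, with Rattus norvegicus as the target (a higher number here means a weaker inhibitor, a lower number a stronger inhibitor), compound 2 stands within the scatter of compound 1, the only measured step being a 2.0-fold higher number from compound 1 to compound 2 (0.30 log units; within the scatter). Compound 3 `C/N=C(\S)[C@]1(c2cccc(F)c2)CCCC[S+]1[O-]` differs from compound 2 by fluoro in place of cyano on an aromatic carbon. The step from compound 1 bears on this change as an exchange at the same aromatic carbon, and it did not leave the scatter. No step beyond the scatter is therefore expected in this assay, and no direction can be expected with confidence. The estimated step is a 1.3-fold higher number from compound 2 to compound 3 (0.10 log units; within the scatter). For compound 3 the expected value is 2000 nM, with an estimated range from 700 nM to 6000 nM.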

Compound 3, concentration for 90% inhibition: 7000 nM
Estimate against measurement, compound 3: 3.5-fold (0.54 log units) below; the measured number lies above the stated range.
By their numbers in this assay, from the lowest: compounds 1 and 2 (each within the scatter of the next); then compound 3.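

In this assay, the position on the aromatic ring proves sensitive to the group it carries: fluoro in place of cyano gives a 4.4-fold higher number from compound 2 to compound 3 (0.64 log units; beyond the scatter), and fluoro in place of trifluoromethyl gives an 8.8-fold higher number from compound 1 to compound 3 (0.94 log units; beyond the scatter). Among the compounds shown here, the exchange between trifluoromethyl and cyano had stayed within the scatter, so fluoro is the first group here to leave it, making compound 3 the weakest of the three. Nothing available accounts for this loss. From the compounds shown here alone, whether chloro or methoxy at this carbon would side with compound 3 or with the other two remains open.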